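Carbonate ester variants and metabolic stability

A few compounds are considered here, and "the series" means these few. Any claim that something is new, unique, unknown or untested is made for them only; others in the source may bear on it.

Measured compounds:
Compound 1 `C[C@@H](O)[C@H]1C(=O)N2C(C(=O)OCOC(=O)OC3Cc4ccccc4C3)=C(S[C@@H]3CN[C@H](C(=O)N(C)C)C3)[C@H](C)[C@H]12`: in a physicochemical assay for metabolic stability, read by HPLC, with a stated time of 120 min, at pH 7.4, tested at 100 uM (on this read-out higher numbers stand for a more stable compound and lower numbers for a less stable compound), compound 1 gives 70%.
Compound 2 `C[C@@H](O)[C@H]1C(=O)N2C(C(=O)OCOC(=O)OC3CCCc4ccccc4C3)=C(S[C@@H]3CN[C@H](C(=O)N(C)C)C3)[C@H](C)[C@H]12`: in this assay compound 2 gives 79%.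
Compound 3 `CC(C)OC(=O)OC(C)OC(=O)C1=C(S[C@@H]2CN[C@H](C(=O)N(C)C)C2)[C@H](C)[C@@H]2[C@@H]([C@@H](C)O)C(=O)N12`: in this assay compound 3 gives 87%; 90% (2 entries).

Among the single numbers in this assay, compound 2 stands highest of two, with compound 1 the nearest, though the difference a number 9 percentage points higher from compound 1 to compound 2 (within the scatter) lies within the scatter. For the measured compounds named here, compound 3 enters with several readings the several entries of compound 3 in this assay, 87%; 90% (2 entries) rather than one number, so no step to it is counted.

Compound 4 `C[C@@H](O)[C@H]1C(=O)N2C(C(=O)OCOC(=O)OC3CCc4ccccc4C3)=C(S[C@@H]3CN[C@H](C(=O)N(C)C)C3)[C@H](C)[C@H]12` remains to be measured. It differs from compound 2 by a group of 10 heavy atoms (10 carbon; one six-membered non-aromatic ring of carbon only, one six-membered aromatic ring of carbon only) in place of a group of 11 heavy atoms (11 carbon; one six-membered aromatic ring of carbon only, one seven-membered non-aromatic ring of carbon only), on an oxygen next to a carbonyl group. Going by the values given here, the only measured step at this position is a number 9 percentage points higher from compound 1 to compound 2 (within the scatter), a change of ring size on the same oxygen, and it was within the scatter. A comparable change is therefore expected to give no step beyond the scatter in this assay. The expected step is a number 3 percentage points lower from compound 2 to compound 4 (within the scatter). Compound 4 is estimated to give 76%, within a range from 64% to 86%.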

Compound 4, percent of the compound remaining: 78%
The estimate for compound 4 lay 2 percentage points below the measured number, within the range that was stated.
By their numbers in this assay, from the lowest: compounds 1, 4 and 2 (each within the scatter of the next).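

In this assay, the step to 1,2,3,4-tetrahydronaphthalen-2-yl on an oxygen next to a carbonyl group is a number 1 percentage points lower from compound 2 to compound 4 (within the scatter), and the step from 2,3-dihydro-1H-inden-2-yl to the same group is a number 8 percentage points higher from compound 1 to compound 4 (within the scatter). With the six-membered non-aromatic ring now read alongside the five- and seven-membered ones, all three steps among these compounds lie within the scatter, so this change in ring size separates none of compounds 1, 2 and 4 on this read-out. No information given here offers a cause for these steps.

As far as these compounds go, it remains open whether an amine or a carboxylic acid carried on the ring would give a step beyond the scatter. The same question stands for a longer open carbon chain in place of the ring at this oxygen.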